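Swapping the aryl group on the saturated ring carbon

The source may report more compounds than this note shows. Statements on the series, on what has been measured and on what is new or still open speak of the compounds shown alone.

Compound 2 `COc1cc(/C=C/C(=O)C2=C(/C=C/c3ccc(O)c(OC)c3)NC(=O)NC2c2c(Cl)cccc2Cl)ccc1O` and compound 1 `COc1cc(/C=C/C(=O)C2=C(/C=C/c3ccc(O)c(OC)c3)NC(=O)NC2c2ccc(C)cc2)ccc1O` share one core and differ only in the group on a saturated ring carbon. In a functional assay, with a stated time of 20 min, tested at 20 uM (a lower number here means a weaker effect, a higher number a stronger effect of the compound at the concentration tested), compound 1 gives 38.2%, and compound 2 gives 31.9%. Compound 2 stands at the lower of the two numbers shown, but the only measured step, a number 6.3 percentage points lower from compound 1 to compound 2 (within the scatter), lies within the scatter, so the two compounds cannot be told apart on this read-out.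

Compound 3 `COc1cc(/C=C/C(=O)C2=C(/C=C/c3ccc(O)c(OC)c3)NC(=O)NC2c2cccc([N+](=O)[O-])c2)ccc1O` has not yet been measured. It differs from compound 2 by 3-nitrophenyl in place of 2,6-dichlorophenyl on a saturated ring carbon. For the measured compounds named here, the one measured step that bears on this change is the earlier exchange of one aryl group for another at the same saturated ring carbon, a number 6.3 percentage points lower from compound 1 to compound 2 (within the scatter), which stayed within the scatter. On that basis no step beyond the scatter is expected in this assay. The estimate amounts to a number 3.1 percentage points higher from compound 2 to compound 3 (within the scatter). Compound 3 is therefore expected to give about 35%, with a range from 22% to 48%.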

Compound 3, a percentage reported as activity, at one concentration (the size of the read-out at that concentration, not a potency): 66.3%
For compound 3 the middle estimate is 31.3 percentage points below the measured one; the measured number lies above the stated range.
By their numbers in this assay, from the lowest: compounds 2 and 1 (each within the scatter of the next); then compound 3.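

With 3-nitrophenyl on the saturated ring carbon, this assay gives a number 34.4 percentage points higher from compound 2 to compound 3 (beyond the scatter) against 2,6-dichlorophenyl and a number 28.1 percentage points higher from compound 1 to compound 3 (beyond the scatter) against 4-methylphenyl. The position therefore does respond to the choice of aryl group, which the pair of compound 1 and compound 2 alone could not show, and compound 3 stands above both of them beyond the scatter. No measurement at hand accounts for this rise.

The compounds shown leave open whether the rise belongs to the nitro group itself or to where it sits on the phenyl ring, and whether other groups on that ring, such as an amine or a carboxylic acid, would give a similar number. For the compounds shown here, the read-out also comes from one concentration, so it shows only that compound 3 has a stronger effect than compound 1 and compound 2 at that concentration.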